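A few compounds are considered here, and "the series" means these few. Any claim that something is new, unique, unknown or untested is made for them only; others in the source may bear on it.

In a functional assay on OVCAR-8 cells (Homo sapiens) (on this read-out higher numbers stand for weaker inhibition of growth and lower numbers for stronger inhibition of growth), compound 1 `O=S(=O)(/C=C/c1ccc(F)cc1)Cc1ccc(Nc2ncnc3ccccc23)cc1` reads 2000 nM and compound 3 `O=S(=O)(/C=C/c1ccc(F)cc1Cl)Cc1ccc(Nc2ncnc3ccccc23)cc1` reads 100000 nM as the higher of these two numbers. Compound 2 `O=S(=O)(/C=C/c1ccc(F)cc1F)Cc1ccc(Nc2ncnc3ccccc23)cc1` reads > 100000 nM which is a limit of the assay and not a number. The change to compound 4 `O=S(=O)(/C=C/c1ccc(C(F)(F)F)cc1F)Cc1ccc(Nc2ncnc3ccccc23)cc1` is 2-fluoro-4-(trifluoromethyl)phenyl in place of 2-chloro-4-fluorophenyl on a double-bonded chain carbon bound to a double-bonded chain carbon with 2-fluoro-4-(trifluoromethyl)phenyl in place of 2-chloro-4-fluorophenyl. Going by the values given here, two measured steps bear on this, both large: an at least 50-fold higher number from compound 1 to compound 2 (1.69 log units; beyond the scatter) for fluoro in place of hydrogen and a 50-fold higher number from compound 1 to compound 3 (1.70 log units; beyond the scatter) for chloro in place of hydrogen. Among the compounds with values here, compound 4 keeps a fluoro, as compound 2 does, but no measured step covers trifluoromethyl. The expected outcome is a 1.4-fold lower number from compound 3 to compound 4 (0.15 log units; within the scatter) with no shift beyond the scatter. Compound 4 is estimated at 70000 nM within a range of 10000 nM to 150000 nM on this read-out.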

Compound 4, concentration for 50% growth inhibition: 100000 nM
Compound 4: middle estimate off by 1.4-fold (0.15 log units), on the low side, and the stated range covers the measured number.
By their numbers in this assay, from the lowest: compound 1; then compounds 3 and 4 (each within the scatter of the next).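

In this assay, 2-fluoro-4-(trifluoromethyl)phenyl in place of 2-chloro-4-fluorophenyl on a double-bonded chain carbon bound to a double-bonded chain carbon gives no change at the digits printed from compound 3 to compound 4 (within the scatter). Against the plain 4-fluorophenyl ring, the new group shows a 50-fold higher number from compound 1 to compound 4 (1.70 log units; beyond the scatter), so the drop in growth inhibition seen with the chloro compound also appears with a ring carrying trifluoromethyl. Compound 2 stands at a limit of the assay. Trifluoromethyl in place of fluoro gives a number no higher from compound 2 to compound 4 (the limit leaves the size open), so the size of this step cannot be read: the limit of > 100000 nM in this assay, at which 1 of the 4 values shown sits.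

Still open, as far as these compounds go, is whether a ring carrying a methoxy group or an amine would read like compound 1 or like compound 4.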